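This account rests on a few compounds, and the source may have more. Where it says the series, first, only, none or still open, it means among the compounds named here.

In a functional assay on HepG2 cells (Homo sapiens) for cytotoxicity, read by MTT assay, with a stated time of 48 h (a higher number here means a weaker inhibitor, a lower number a stronger inhibitor), two compounds on a shared core have been measured so far. Compound 1 (`CCCCSCC(=O)N1N=C(c2cc3ccccc3oc2=O)C[C@@H]1c1ccccc1`) gives 6640 nM, and compound 2 (`O=C(CSc1ccc([N+](=O)[O-])cc1)N1N=C(c2cc3ccccc3oc2=O)C[C@@H]1c1ccc(C(F)(F)F)cc1`) gives 7760 nM. These values lie within the scatter of each other, so compound 2 stands level with compound 1. Among the compounds with values here, the pair differs in more than one place, and no measured pair isolates a single change.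

Compound 3 (`CCCCSCC(=O)N1N=C(c2cc3ccccc3oc2=O)C[C@@H]1c1ccc(C(F)(F)F)cc1`) is compound 2 with one change: butyl in place of 4-nitrophenyl on a sulfur. Compound 1 also carries butyl on its sulfur and gives 6640 nM, while compound 2, with 4-nitrophenyl there, gives 7760 nM. This is only a weak hint, since the two compounds differ elsewhere as well, but it offers no sign that the swap matters much. No step beyond the scatter is therefore expected in this assay, in either direction. The estimated change is a 1.1-fold lower number from compound 2 to compound 3 (0.04 log units; within the scatter). For compound 3 the expected value is 7000 nM, with an estimated range from 3000 nM to 16000 nM.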

Compound 3, half-maximal inhibitory concentration: 8680 nM
Compound 3: the middle estimate sits 1.2-fold (0.09 log units) below what was measured; the range from low to high includes it.
By their numbers in this assay, from the lowest: compounds 1, 2 and 3 (each within the scatter of the next).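

In this assay, within the data shown here, putting butyl in place of 4-nitrophenyl on the sulfur gives a 1.1-fold higher number from compound 2 to compound 3 (0.05 log units; within the scatter), the first reading of this swap on its own, with everything else in the molecule held the same. Although the swap removes a six-membered aromatic ring and replaces 9 heavy atoms with 4, the two numbers lie within the scatter, so this pair shows no measurable difference between these two groups at this position. Compound 3 also isolates a second single change, trifluoromethyl in place of hydrogen on an aromatic carbon, which gives a 1.3-fold higher number from compound 1 to compound 3 (0.12 log units; within the scatter), and this step also lies within the scatter.

On these data alone, these two steps say nothing about other groups on the sulfur, so it remains open whether a carboxylic acid, an amine or a chain much longer than butyl would produce a step beyond the scatter, or whether a fluorine or methoxy group in place of the trifluoromethyl would do so. Nothing available here offers an explanation for how these compounds affect the cells.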